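Chloro in place of bromo: compound 1 to compound 4

The source may report more compounds than this note shows. Statements on the series, on what has been measured and on what is new or still open speak of the compounds shown alone.

In a functional assay on CCRF-HSB-2 cells (Homo sapiens) for antiproliferative activity (a higher number here means a weaker inhibitor, a lower number a stronger inhibitor), compound 1 (`O=c1[nH]c(=O)n([C@@H]2S[C@H](CO)[C@@H](O)[C@@H]2O)cc1/C=C/Br`) gives > 100 ug/mL, which is a limit. Compound 2 (`O=c1[nH]c(=O)n([C@H]2S[C@H](CO)[C@@H](O)[C@@H]2O)cc1/C=C/Br`) gives > 100 ug/mL, also a limit. Among the measured compounds shown here, compound 3 (`Nc1ncnc2c1ncn2[C@@H]1S[C@H](CO)[C@@H](O)[C@@H]1O`) gives 14.8 ug/mL, the only value that is a number. Compound 1 therefore sits at the limit of > 100 ug/mL in this assay, at which 2 of the 3 values shown sit. For the measured compounds named here, the one measured step, a step that the two limits leave unreadable from compound 1 to compound 2, is a change of configuration only, (the fact that compounds 1 and 2 differ only in the configuration as drawn), and gives no size. Compound 4 (`O=c1[nH]c(=O)n([C@@H]2S[C@H](CO)[C@@H](O)[C@@H]2O)cc1/C=C/Cl`) carries this change: chloro in place of bromo on a double-bonded chain carbon bound to a double-bonded chain carbon. Going by the values given here, no measured step covers chloro in place of bromo, so no step beyond the scatter is expected in this assay, in either direction. The expected step is a step that the limit leaves unreadable from compound 1 to compound 4. Compound 4 is estimated at 130 ug/mL, with a range of 70 ug/mL to 250 ug/mL.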

Compound 4, half-maximal inhibitory concentration: > 100 ug/mL
Compound 4: a limit, no number; the forecaster's own chance of this, stated with the estimate: 80%; the middle value lies beyond the limit too.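

No step can be read from compound 1 to compound 4, since both results are limits and not numbers: the limit of > 100 ug/mL in this assay, at which 3 of the 4 values shown sit. Going by these compounds, whether chloro in place of bromo shifts potency at all, in either direction, stays open.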